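Ring-opened amide replacing aryl sulfonamide in the shared core

The source may report more compounds than this note shows. Statements on the series, on what has been measured and on what is new or still open speak of the compounds shown alone.

Measured so far:
compound 1 `CCOC(=O)[C@@H]1CCCN(S(=O)(=O)c2ccc(S(=O)(=O)N(CC)C(C)C)cc2)C1`: 1600 nM
compound 2 `CCOC(=O)[C@@H]1CCCN(S(=O)(=O)c2ccc(S(=O)(=O)N3CCCCC3)cc2)C1`: 3300 nM

In a functional assay on BXPC-3 cells (Homo sapiens) for inhibition, read by MTT assay, with a stated time of 7 days (on this read-out lower numbers stand for stronger inhibition and higher numbers for weaker inhibition), compound 1 gives 1600 nM and compound 2 gives 3300 nM. Compound 2 therefore stands at the highest of the two numbers, the weaker end of the pair, with compound 1 as its nearest neighbour, a 2.1-fold higher number from compound 1 to compound 2 (0.31 log units; beyond the scatter).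

Compound 3 `CCOC(=O)[C@@H]1CCCN(S(=O)(=O)c2ccc(C(=O)N(CC)CC)cc2)C1` is not yet measured. It differs from compound 2 as follows: diethylcarbamoyl in place of (piperidin-1-yl)sulfonyl on an aromatic carbon. Among the compounds with values here, the one measured step bears on this only indirectly: it shows that changing the group on the sulfonyl sulfur from ethyl(isopropyl)amino to piperidin-1-yl moved the number modestly, a 2.1-fold higher number from compound 1 to compound 2 (0.31 log units; beyond the scatter). Within the data shown here, no measured pair shows the exchange of the sulfonyl itself for a carbonyl, so that part of the change has no precedent here. Given only the modest size of the one known step, compound 3 is expected to land near compound 2, a 1.3-fold lower number from compound 2 to compound 3 (0.12 log units; within the scatter), with wide uncertainty in either direction. Compound 3 is thus estimated at 2500 nM, within a range of 700 nM to 9000 nM.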

Compound 3, half-maximal inhibitory concentration: 640 nM
Estimate against measurement, compound 3: 3.9-fold (0.59 log units) above, and the stated range ends above it.
By their numbers in this assay, from the lowest: compound 3; then compound 1; then compound 2.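

In this assay, diethylcarbamoyl on the aromatic carbon para to a large group gives a 5.2-fold lower number from compound 2 to compound 3 (0.71 log units; beyond the scatter) when it replaces (piperidin-1-yl)sulfonyl, and a 2.5-fold lower number from compound 1 to compound 3 (0.40 log units; beyond the scatter) when it replaces ethyl(isopropyl)sulfamoyl. The earlier pair varied only the group on the sulfonyl sulfur, whereas these steps exchange the sulfonyl itself for a carbonyl along with the amine part; both run the same way, beyond the scatter, which makes compound 3 the strongest of the three in this assay and shows that the sulfonyl is not required at this position for activity here. No supporting data on mechanism or properties accompany these results, so the shift stays an observation without an explanation.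

The compounds shown leave open how much of the shift belongs to the carbonyl and how much to the amine part, since each step changes both; a diethylsulfamoyl group or a piperidine-1-carbonyl group would separate the two. Also open, going by these compounds, is whether the amide tolerates a longer chain on its nitrogen, and how the ethyl ester on the shared core compares with a carboxylic acid.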